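Replacing the 4-acetamidophenyl group of compound 3

A few compounds are considered here, and "the series" means these few. Any claim that something is new, unique, unknown or untested is made for them only; others in the source may bear on it.

In a functional assay on PC-3 cells (Homo sapiens) for inhibition, read by sulforhodamine B assay, with a stated time of 48 h, tested at 50 uM (on this read-out higher numbers stand for more inhibition of growth at the one concentration tested and lower numbers for less inhibition of growth), compound 1 (`COc1ccc([C@@H]2C/C(=N/OCc3cn(-c4ccc(O)cc4)nn3)c3cc(CC=C(C)C)c(OC)cc3O2)cc1`) gives 64% and compound 2 (`COc1ccc([C@@H]2C/C(=N/OCc3cn(-c4cccc(CO)c4)nn3)c3cc(CC=C(C)C)c(OC)cc3O2)cc1`) gives 34%, while compound 3 (`COc1ccc([C@@H]2C/C(=N/OCc3cn(-c4ccc(NC(C)=O)cc4)nn3)c3cc(CC=C(C)C)c(OC)cc3O2)cc1`) gives 2% and stands lowest of the three. Compound 4 (`COc1ccc([C@@H]2C/C(=N/OCc3cn(-c4cccnc4Cl)nn3)c3cc(CC=C(C)C)c(OC)cc3O2)cc1`) carries 2-chloropyridin-3-yl in place of 4-acetamidophenyl on an aromatic nitrogen.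

Three measured steps change the same group. Two of them arrive at the 4-acetamidophenyl group and are large (a number 62 percentage points lower from compound 1 to compound 3 (beyond the scatter); a number 32 percentage points lower from compound 2 to compound 3 (beyond the scatter)). The third is modest (a number 30 percentage points lower from compound 1 to compound 2 (beyond the scatter)). Both other groups thus give higher numbers than the 4-acetamidophenyl group, though that comparison rests on three compounds only. Among the compounds with values here, no measured compound carries a chlorine or a pyridine ring, which leaves the size of the step poorly defined.

Within the data shown here, a rise similar to the one seen between compound 2 and compound 3 seems the best guess. In this assay the expected step is a number 28 percentage points higher from compound 3 to compound 4 (beyond the scatter) and its size is only an estimate. Compound 4 is expected at 30% (estimated range 5% to 60%).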

Compound 4, percent growth inhibition at one concentration: 44%
For compound 4 the middle estimate is 14 percentage points below the measured one, within the range that was stated.
By their numbers in this assay, from the lowest: compound 3; then compounds 2 and 4 (each within the scatter of the next); then compound 1.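

In this assay the group on the aromatic nitrogen of the five-membered ring again sets the number: the step is a number 42 percentage points higher from compound 3 to compound 4 (beyond the scatter) and shows that a group with 0 hydrogen-bond donors and one six-membered aromatic ring with 1 hetero atom also stands above the 4-acetamidophenyl group. Against the 3-(hydroxymethyl)phenyl group the step is a number 10 percentage points higher from compound 2 to compound 4 (within the scatter) and gives no order between these two groups, while against the 4-hydroxyphenyl group the step is a number 20 percentage points lower from compound 1 to compound 4 (beyond the scatter) and leaves compound 1 the highest of the four. Nothing measured here bears on the reason for these steps.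

The compounds shown do not separate the chlorine from the ring nitrogen of the 2-chloropyridin-3-yl group. From the compounds shown here alone, how a plain phenyl, a 3-chlorophenyl or a 4-aminophenyl group on the same nitrogen would compare also stays open.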